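From 2-fluorophenyl to 3-fluorophenyl: compound 3 to compound 4

A few compounds are considered here, and "the series" means these few. Any claim that something is new, unique, unknown or untested is made for them only; others in the source may bear on it.

Measured so far in an ADME assay on Vero 76 cells (Chlorocebus sabaeus) for cytotoxicity, read by crystal violet staining, with a stated time of 96 h; a higher number here means that more compound is tolerated, a lower number that less compound is tolerated
Compound 1 `COc1cccc(NC(=S)Nc2cccc(C(F)(F)F)c2)c1` gives 20000 nM
Compound 2 `Fc1ccc(NC(=S)Nc2cccc(C(F)(F)F)c2)cc1` gives 40000 nM
Compound 3 `Fc1ccccc1NC(=S)Nc1cccc(C(F)(F)F)c1` gives 64000 nM

Compound 3 lies above compound 1, beyond the scatter, but within the scatter of compound 2. Compound 4 `Fc1cccc(NC(=S)Nc2cccc(C(F)(F)F)c2)c1` carries 3-fluorophenyl in place of 2-fluorophenyl on an amide-type nitrogen and remains unmeasured. Among the compounds with values here, one measured step bears on this change, a swap of 4-fluorophenyl for 2-fluorophenyl at the same place, and it shows a 1.6-fold higher number from compound 2 to compound 3 (0.20 log units; within the scatter) without leaving the scatter. No step beyond the scatter is therefore expected. The expected change is a 1.6-fold lower number from compound 3 to compound 4 (0.20 log units; within the scatter) and it stays within the scatter. Compound 4 is estimated at 40000 nM with an expected range from 18000 nM to 85000 nM in this measurement.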

Compound 4, half-maximal cytotoxic concentration: 20000 nM
The estimate for compound 4 lay 2.0-fold (0.30 log units) above the measured number; measured number inside the range.
By their numbers in this assay, from the lowest: compounds 1, 4, 2 and 3 (each within the scatter of the next, the first and the last beyond it).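

In this assay, 3-fluorophenyl in place of 2-fluorophenyl on the amide-type nitrogen gives a step beyond the scatter (a 3.2-fold lower number from compound 3 to compound 4 (0.51 log units; beyond the scatter)), unlike the earlier swap between the 4-fluorophenyl and 2-fluorophenyl groups. Beside that, 3-fluorophenyl in place of 4-fluorophenyl stays within the scatter (a 2.0-fold lower number from compound 2 to compound 4 (0.30 log units; within the scatter)), and fluoro in place of methoxy on an aromatic carbon leaves the number unchanged (no change at the digits printed from compound 1 to compound 4 (within the scatter)). Nothing measured here accounts for the gap between compound 3 and compound 4. As far as these compounds go, whether a chloro group or an amine on this ring would follow the fluoro compounds remains open.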